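Bromo for Methyl on Two Related Cores

The source may report more compounds than this note shows. Statements on the series, on what has been measured and on what is new or still open speak of the compounds shown alone.

Compound 1 `COC(=O)[C@@]1(C)CCC=C2[C@@H]1CC[C@@H](C)[C@]2(C)Cc1c[nH]c2ccc(C)cc12` and compound 2 `COC(=O)[C@@]1(C)CCC=C2[C@@H]1CC[C@@H](C)[C@]2(C)Cc1c[nH]c2ccc(Br)cc12` share one core and differ in a single place. In a functional assay on A549 cells (Homo sapiens) for inhibition, read by sulforhodamine B assay, with a stated time of 48 h (a lower number here means a stronger inhibitor of growth, a higher number a weaker inhibitor of growth), compound 1 gives 17000 nM, and compound 2 gives 15000 nM. The change between them is bromo in place of methyl on an aromatic carbon, and its step is a 1.1-fold lower number from compound 1 to compound 2 (0.05 log units; within the scatter), so the two numbers cannot be told apart.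

Compound 3 `COC(=O)[C@@]1(C)CC[C@@H]2C3=C1CC[C@@H](C)[C@]3(C)C[C@@H]1c3cccc(C)c3N[C@H]21` is built from the same atoms as compound 1, joined differently; the difference between the two cores is not broken down here. In this assay compound 3 gives 30000 nM. Its number and those of compound 1 and compound 2 all lie within the usual scatter of one another, so no order among the three can be claimed.

Compound 4 `COC(=O)[C@@]1(C)CC[C@@H]2C3=C1CC[C@@H](C)[C@]3(C)C[C@@H]1c3cccc(Br)c3N[C@H]21` has not yet been measured. It differs from compound 3 by bromo in place of methyl on an aromatic carbon. This is the same kind of change as that from compound 1 to compound 2, but not the same: in compound 3 the ring carrying the group is part of a fused or bridged system of five rings, ortho to a fused ring and meta to a fused ring, whereas in compound 1 it is part of a fused or bridged system of two rings, meta to a fused ring and para to a fused ring.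

The step from compound 3 to compound 4 is expected to be a 1.1-fold lower number from compound 3 to compound 4 (0.05 log units; within the scatter), because the comparable step a 1.1-fold lower number from compound 1 to compound 2 (0.05 log units; within the scatter) was within the scatter. Compound 4 is therefore estimated to give about 27000 nM in this assay, most likely between 12000 nM and 60000 nM.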

Compound 4, concentration for 50% growth inhibition: 42000 nM
Compound 4: middle estimate off by 1.6-fold (0.19 log units), on the low side, and the stated range covers the measured number.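

In this assay, bromo in place of methyl on an aromatic carbon gives a 1.4-fold higher number from compound 3 to compound 4 (0.15 log units; within the scatter), so compound 3 and compound 4 cannot be told apart, just as compound 1 and compound 2 could not. Set side by side, the two steps also cannot be told apart: the same change on two cores in this assay, a 1.1-fold lower number (0.05 log units; within the scatter) from compound 1 to compound 2 and a 1.4-fold higher number (0.15 log units; within the scatter) from compound 3 to compound 4, 1.6-fold (0.20 log units) apart, within the scatter of two such steps. This shows that, in these two pairs, the swap carries from one core to the other with no measurable effect on the growth-inhibition number, even though the group sits in a different ring environment on each core; it does not show that the swap would be equally silent on any other core, in any other assay or at any other place on these molecules, and two pairs are too few to make a rule.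

The compounds shown carry only methyl or bromo at these aromatic carbons, so it remains open what chloro, methoxy, an amine or a carboxylic acid would do there. Also open, from the compounds shown here alone, is whether replacing the methyl ester shared by all four compounds with an amide or a carboxylic acid would move the number beyond the usual scatter.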